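Benzyl urea series: half-lives at the assay ceiling

A few compounds are considered here, and "the series" means these few. Any claim that something is new, unique, unknown or untested is made for them only; others in the source may bear on it.

compound 1 `O=C(NCc1ccc(C(F)(F)F)cc1)N1C(=O)c2ccccc2S1(=O)=O`: > 166 h
compound 2 `O=C(NCc1ccccc1C(F)(F)F)N1C(=O)c2ccccc2S1(=O)=O`: > 166 h
compound 3 `O=C(NCc1ccccc1)N1C(=O)c2ccccc2S1(=O)=O`: > 166 h

All three compounds share one core and differ only in the group on the aromatic carbon. In a physicochemical assay for pharmacokinetics (a lower number here means that the compound disappears faster, a higher number that the compound lasts longer), none of them gives a number: each value is a limit of the assay. Compound 3 stands at that limit. Compound 1 and compound 2 stand at the same limit, (the limit of > 166 h in this assay, at which 3 of the 3 values shown sit). The two steps that lead to compound 3, a step that the two limits leave unreadable from compound 1 to compound 3 and a step that the two limits leave unreadable from compound 2 to compound 3, are therefore unreadable in size, and whether trifluoromethyl against hydrogen moves the half-life cannot be told from these data.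

Compound 4, `COc1cccc(CNC(=O)N2C(=O)c3ccccc3S2(=O)=O)c1`, is not yet measured. It differs from compound 3 by methoxy in place of hydrogen on an aromatic carbon. Within the data shown here, no measured step involves a methoxy, and the two steps that exist have no readable size. Among the measured compounds shown here, the only guide is that every measured value sits at the limit, (the limit of > 166 h in this assay, at which 3 of the 3 values shown sit). Compound 4 is therefore expected to sit at or near that limit as well, the step that the limit leaves unreadable from compound 3 to compound 4 amounting to nothing readable. The half-life of compound 4 in this assay is estimated at 200 h, in the range 80 h to 600 h, with a high chance that the assay again reports only a limit.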

Compound 4, half-life: > 166 h
Compound 4: a limit, no number; the forecaster's own chance of this, stated with the estimate: 85%; the middle value is on the limit's open side.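

No size can be read for the step between compound 3 and compound 4 in this assay because both compounds stand at the same limit: the limit of > 166 h in this assay, at which 4 of the 4 values shown sit. The compounds shown leave open whether methoxy or trifluoromethyl in place of hydrogen moves the half-life at all, and how long any of the four compounds actually lasts.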